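The source may report more compounds than this note shows. Statements on the series, on what has been measured and on what is new or still open speak of the compounds shown alone.

Compound 1, `Clc1ccc2nc(Nc3nc4ccccc4s3)sc2c1`. In a functional assay on B16-F10 cells (Mus musculus) for cytotoxicity, read by MTT assay, with a stated time of 48 h (a higher number here means a weaker inhibitor, a lower number a stronger inhibitor), compound 1 gives > 50000 nM, which is a limit of the assay rather than a number.

Compound 2, `S=C(Nc1ccccc1)Nc1nc2c(Cl)cccc2s1`. In this assay compound 2 gives > 50000 nM, again a limit of the assay and not a number.

Compound 3, `Fc1ccc2nc(Nc3nc4ccc(Cl)cc4s3)sc2c1`. In this assay compound 3 gives 41900 nM.

Compound 3 differs from compound 1 in a single place, (fluoro in place of hydrogen on an aromatic carbon), and this change made an at least 1.1-fold lower number from compound 1 to compound 3 (0.07 log units; that floor lies within the scatter). Compound 2 is built on a different core from compound 1; how the two cores differ is not broken down here. Compound 2 is one of the values sitting at the limit of > 50000 nM in this assay, at which 2 of the 3 values shown sit.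

Compound 4, `Fc1ccc(NC(=S)Nc2nc3c(Cl)cccc3s2)cc1`, has not yet been measured in this assay. It differs from compound 2 by fluoro in place of hydrogen on an aromatic carbon. Within the data shown here, this is the same kind of change as the one from compound 1 to compound 3, but the place is not the same: in compound 3 the fluoro sits on a six-membered aromatic ring of carbon only that is part of a fused or bridged system of two rings, meta to a fused ring and para to a fused ring, whereas in compound 4 it sits on a six-membered aromatic ring of carbon only, para to a large group, so that phenyl becomes 4-fluorophenyl.

For compound 4 in this assay the expected step is a step that the limit leaves unreadable from compound 2 to compound 4, a small one, resting on compound 2 sitting at > 50000 nM and on the same kind of change having made only an at least 1.1-fold lower number from compound 1 to compound 3 (0.07 log units; that floor lies within the scatter). Compound 4 is therefore expected to give roughly 60000 nM, somewhere between 25000 nM and 150000 nM, and there is a fair chance that the assay again reports only a limit.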

Compound 4, half-maximal inhibitory concentration: > 50000 nM
Compound 4 was reported as a limit; the forecaster's own chance of this, stated with the estimate: 60%; the middle value is on the limit's open side.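

In this assay compound 4 gives > 50000 nM, which is a limit of the assay and not a number. No step can be read from compound 2 to compound 4, because both sit at a limit: the limit of > 50000 nM in this assay, at which 3 of the 4 values shown sit.

The compounds shown leave open whether 4-fluorophenyl in place of phenyl changes the number at all on this thiourea-bearing pair.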